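The source may hold more compounds than are shown below. What is called first, only, known or untested is meant among the compounds shown, and "the series" means these compounds.

In a functional assay on HT-29 cells (Homo sapiens) for inhibition, read by MTT assay, with a stated time of 72 h (a higher number here means a weaker inhibitor, a lower number a stronger inhibitor), three compounds have been measured:

Compound 1 `COc1cc2c(Oc3ccc(NC(=O)c4nn(-c5ccccc5C)c(=O)cc4C)cc3F)ccnc2cc1OCCCN1CCC(C)CC1` gives 2810 nM.
Compound 2 `COc1cc2c(Oc3ccc(NC(=O)c4nn(-c5ccccc5C)c(=O)cc4C)cc3F)ccnc2cc1OCCCN1CCN(C)CC1` gives 3790 nM.
Compound 3 `COc1ccc(-n2nc(C(=O)Nc3ccc(Oc4ccnc5cc(OCCCN6CCC(C)CC6)c(OC)cc45)c(F)c3)c(C)cc2=O)cc1` gives 5450 nM.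

Compound 1 and compound 2 share a core and differ in one place: 4-methylpiperazin-1-yl in place of 4-methylpiperidin-1-yl on a saturated chain carbon, three bonds along the chain from an oxygen on an aromatic ring. That change gave a 1.3-fold higher number from compound 1 to compound 2 (0.13 log units; within the scatter). Compound 3 differs from compound 1 in another place: 4-methoxyphenyl in place of 2-methylphenyl on an aromatic nitrogen, and this gave a 1.9-fold higher number from compound 1 to compound 3 (0.29 log units; within the scatter). The values of compound 2 and compound 3 lie within the scatter of each other.

Compound 4 `COc1ccc(-n2nc(C(=O)Nc3ccc(Oc4ccnc5cc(OCCCN6CCN(C)CC6)c(OC)cc45)c(F)c3)c(C)cc2=O)cc1` is not yet measured. It differs from compound 3 in the following way: 4-methylpiperazin-1-yl in place of 4-methylpiperidin-1-yl on a saturated chain carbon, three bonds along the chain from an oxygen on an aromatic ring. This is the same change as that from compound 1 to compound 2, made at a place described in the same words. Because a 1.3-fold higher number from compound 1 to compound 2 (0.13 log units; within the scatter) stayed within the scatter, compound 4 is expected to show a 1.3-fold higher number from compound 3 to compound 4 (0.11 log units; within the scatter) in this assay. Compound 4 is therefore estimated at 7100 nM, most likely between 3500 nM and 14500 nM.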

Compound 4, half-maximal inhibitory concentration: 3520 nM
Compound 4: the middle estimate sits 2.0-fold (0.30 log units) above what was measured; measured number inside the range.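

In this assay, 4-methylpiperazin-1-yl in place of 4-methylpiperidin-1-yl gave a 1.5-fold lower number from compound 3 to compound 4 (0.19 log units; within the scatter), and this does not differ from the earlier step on the other core: the same change on two cores in this assay, a 1.3-fold higher number (0.13 log units; within the scatter) from compound 1 to compound 2 and a 1.5-fold lower number (0.19 log units; within the scatter) from compound 3 to compound 4, 2.1-fold (0.32 log units) apart, within the scatter of two such steps. Likewise, 4-methoxyphenyl in place of 2-methylphenyl on the aromatic nitrogen gave a 1.1-fold lower number from compound 2 to compound 4 (0.03 log units; within the scatter), again without a difference from the earlier step: the same change on two cores in this assay, a 1.9-fold higher number (0.29 log units; within the scatter) from compound 1 to compound 3 and a 1.1-fold lower number (0.03 log units; within the scatter) from compound 2 to compound 4, 2.1-fold (0.32 log units) apart, within the scatter of two such steps. Among the compounds shown here, both changes thus carried from one core to the other without a detectable difference, but every step lies within the scatter, so this shows only that neither change moved the number measurably on either core, not that a real effect transfers.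

The compounds shown leave open what a morpholine or a dimethylamino group would do at the end of the propyl chain, or a shorter or longer chain. They also leave open whether an unsubstituted phenyl or a pyridyl ring on the aromatic nitrogen would give a step beyond the scatter.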